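The source may report more compounds than this note shows. Statements on the series, on what has been measured and on what is new or still open speak of the compounds shown alone.

In a functional assay on SK-OV-3 cells (Homo sapiens) for inhibition, read by CCK-8 assay, with a stated time of 70 h (on this read-out higher numbers stand for weaker inhibition and lower numbers for stronger inhibition), compound 1 `O=C(O)c1cccc(COc2ccc(OCCOCCNC3CCCC3)cc2)c1` gives > 100000 nM, which is a limit and not a number. Compound 2 `COC(=O)c1ccccc1COc1ccc(OCCOCCNC2CCCC2)cc1` also stands only at a limit, > 100000 nM. Going by the values given here, the one measured step, a step that the two limits leave unreadable from compound 1 to compound 2, has no size to carry forward, and the only guide is the limit of > 100000 nM in this assay, at which 2 of the 2 values shown sit. Compound 3 `O=[N+]([O-])c1cccc(COc2ccc(OCCOCCNC3CCCC3)cc2)c1` differs from compound 2 in one place: 3-nitrophenyl in place of 2-(methoxycarbonyl)phenyl on a saturated chain carbon bound to an oxygen on an aromatic ring. No shift beyond the scatter is expected, and the estimated step is a number no higher from compound 2 to compound 3 (the limit leaves the size open). For compound 3 the estimated value is 100000 nM, with an expected range of 30000 nM to 300000 nM.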

Compound 3, half-maximal inhibitory concentration: 15400 nM
Compound 3: middle estimate off by 6.5-fold (0.81 log units), on the high side; the measured number lies below the stated range.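

With 3-nitrophenyl on a saturated chain carbon bound to an oxygen on an aromatic ring, this assay gives its only measured number among these compounds, so a change in this place can move the read-out off the limit. The change gives an at least 6.4-fold lower number from compound 2 to compound 3 (0.81 log units; beyond the scatter), and nitro in place of carboxy on an aromatic carbon gives an at least 6.4-fold lower number from compound 1 to compound 3 (0.81 log units; beyond the scatter). Both sizes remain open-ended, set against a limit: the limit of > 100000 nM in this assay, at which 2 of the 3 values shown sit.

The compounds shown leave open how large these steps really are. They also leave open whether an amine or a nitrile on that aromatic carbon would give a measurable number as well.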